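This account rests on a few compounds, and the source may have more. Where it says the series, first, only, none or still open, it means among the compounds named here.

Measured compounds:
compound 1 `CC(C)(C)OC(=O)N1CCC(O[C@H]2CC[C@@H](Oc3ccc(S(C)(=O)=O)cc3)CC2)CC1`: 121%
compound 2 `CC(C)(C)OC(=O)N1CCC(O[C@H]2CC[C@H](Oc3ccc(C#N)cc3)CC2)CC1`: 106%
compound 3 `Cc1nc(O[C@H]2CC[C@H](OC3CCN(C(=O)OC(C)(C)C)CC3)CC2)ccc1C(=O)N(C)C`: 111%

All three were tested in a functional assay on isolated protein for agonist activity at Glucose-dependent insulinotropic receptor (Rattus norvegicus), read by HTRF and cAMP accumulation; a lower number here means a smaller maximal response, a higher number a larger maximal response. Each reaches a maximal response at or above that of the reference, so all three behave as full agonists here. Compound 2 gives the smallest number of the three, but its gap to compound 3 falls within the usual scatter, so those two cannot be told apart; only compound 1 stands beyond the scatter, with a larger maximal response than compound 2.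

The unmeasured compound 4 `CC(C)(C)OC(=O)N1CCC(O[C@H]2CC[C@H](Oc3cnc(S(C)(=O)=O)cn3)CC2)CC1` is reached from compound 2 by one change: 5-(methylsulfonyl)pyrazin-2-yl in place of 4-cyanophenyl on an oxygen on a saturated carbon. Going by the values given here, no measured pair shows this change, so its effect in this assay is not known from the numbers at hand. Since every measured compound gives a full response, the change is expected to move the maximal response by little, if at all, and not beyond the scatter; the expected step is a number 4 percentage points higher from compound 2 to compound 4 (within the scatter). Compound 4 is therefore estimated at 110%, with a likely range from 95% to 125%.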

Compound 4, largest response reached (Emax), in percent of the reference or control that the assay uses: 110%
For compound 4 middle estimate and measured number coincide at the digits printed; measured number inside the range.
By their numbers in this assay, from the lowest: compounds 2, 4, 3 and 1 (each within the scatter of the next, the first and the last beyond it).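

In this assay, putting 5-(methylsulfonyl)pyrazin-2-yl in place of 4-cyanophenyl on an oxygen on a saturated carbon gives a number 4 percentage points higher from compound 2 to compound 4 (within the scatter). Going by these compounds alone, this is the first direct reading at this position: a group of 10 heavy atoms with a ring holding 2 hetero atoms stands in for one of 8 heavy atoms with a ring of carbon only, and the pair cannot be told apart. The nitrile is therefore not needed for a full response in this pair, and nothing at hand explains the outcome.

Going by these compounds, whether the position would tolerate a quite different group, such as a carboxylic acid or an amine in place of the methylsulfonyl, remains open. So does how much of each compound is needed, since this assay reports only the largest response.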